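The source may report more compounds than this note shows. Statements on the series, on what has been measured and on what is new or still open speak of the compounds shown alone.

Compound 1, `Oc1ccc(-c2cc(-c3ccco3)cc(-c3cccc(O)c3)n2)cc1`, compound 2, `Oc1ccc(-c2cc(-c3ccco3)cc(-c3ccc(O)cc3)n2)cc1`, and compound 3, `Oc1cccc(-c2cc(-c3ccoc3)cc(-c3ccccc3O)n2)c1`, were each tested in a functional assay on DU-145 cells (Homo sapiens) for cytotoxicity, read by CCK-8 assay (on this read-out higher numbers stand for weaker inhibition and lower numbers for stronger inhibition), and compound 4, `Oc1ccc(-c2cc(-c3ccoc3)cc(-c3ccccc3O)n2)cc1`, awaits its measurement there.

In this assay compound 1 gives 2070 nM. Compound 2 reaches only a limit of the assay, > 50000 nM. The change from compound 1 to compound 2 is 4-hydroxyphenyl in place of 3-hydroxyphenyl on an aromatic carbon, and it made a step of an at least 24-fold higher number from compound 1 to compound 2 (1.38 log units; beyond the scatter); this step ends at the limit of > 50000 nM in this assay, at which 1 of the 3 values shown sits. Compound 3 gives 2790 nM in this assay, a number that sits within the usual scatter of the number of compound 1, so the two are not distinguished here. How the core of compound 3 differs from the core of compound 1 is not broken down here.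

Compound 4 arises from compound 3 by 4-hydroxyphenyl in place of 3-hydroxyphenyl on an aromatic carbon. This is the same kind of change as that from compound 1 to compound 2, but not the same: in compound 3 the place is meta to a 2-hydroxyphenyl group and meta to a furan-3-yl group, whereas in compound 1 it is meta to a 4-hydroxyphenyl group and meta to a furan-2-yl group. Judging from the one earlier step, compound 4 is expected to be much weaker than compound 3, with a step estimated at a 14-fold higher number from compound 3 to compound 4 (1.16 log units; beyond the scatter). That expectation rests on the step of an at least 24-fold higher number from compound 1 to compound 2 (1.38 log units; beyond the scatter), which ends at the limit of > 50000 nM in this assay, at which 1 of the 3 values shown sits, and there is a fair chance that compound 4 likewise ends only at a limit. In this assay compound 4 is thus estimated at 40000 nM, likely between 8000 nM and 150000 nM.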

Compound 4, half-maximal inhibitory concentration: 28000 nM
Compound 4: middle estimate off by 1.4-fold (0.15 log units), on the high side; measured number inside the range.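

In this assay, 4-hydroxyphenyl in place of 3-hydroxyphenyl on an aromatic carbon next to the ring nitrogen gave a 10-fold higher number from compound 3 to compound 4 (1.00 log units; beyond the scatter), so on this second core the change again went with weaker inhibition, as it had on the core of compound 1. Set side by side, the two steps compare as follows: the same change on two cores in this assay, an at least 24-fold higher number (1.38 log units; beyond the scatter) from compound 1 to compound 2 and a 10-fold higher number (1.00 log units; beyond the scatter) from compound 3 to compound 4; the limit leaves it open whether they differ. Compound 2 gives > 50000 nM, which is a limit of the assay and not a number, and two cores show only that the direction of the change held in these two pairs, not that it would hold across the series or that its size carries over.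

The compounds shown leave open how the change behaves on a core where the furan-2-yl or furan-3-yl group gives way to another group, such as an amine or a carboxylic acid, and how much of the result depends on the 2-hydroxyphenyl group that sits in compound 3 and compound 4. They also leave open whether a methoxy group or an amine in place of the hydroxyl of the 4-hydroxyphenyl group would go with stronger or weaker inhibition in this assay.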